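A few compounds are considered here, and "the series" means these few. Any claim that something is new, unique, unknown or untested is made for them only; others in the source may bear on it.

In a functional assay on PC-3 cells (Homo sapiens) for antiproliferative activity, read by MTT assay, with a stated time of 24 h (on this read-out higher numbers stand for weaker inhibition and lower numbers for stronger inhibition), three compounds that share one core and differ only on an amide-type nitrogen have been measured. Compound 1 `CCn1c(C(=O)N[C@@H](C)C(=O)OC)ccc1C(CC)(CC)c1ccc(OCS(=O)(=O)c2ccccc2)c(C)c1` gives > 50000 nM, which is a limit of the assay and not a number. Compound 2 `CCn1c(C(=O)NCCNC(=O)OC(C)(C)C)ccc1C(CC)(CC)c1ccc(OCS(=O)(=O)c2ccccc2)c(C)c1` gives > 50000 nM, again a limit of the assay. Among the compounds with values here, compound 3 `CCn1c(C(=O)NC2(CO)CC2)ccc1C(CC)(CC)c1ccc(OCS(=O)(=O)c2ccccc2)c(C)c1` gives 3560 nM, the only true number of the three, and it is the strongest inhibitor so far. Two large measured steps place it there: an at least 14-fold lower number from compound 1 to compound 3 (1.14 log units; beyond the scatter), and an at least 14-fold lower number from compound 2 to compound 3 (1.14 log units; beyond the scatter). The step that the two limits leave unreadable from compound 1 to compound 2 cannot be read.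

Compound 4 `CCn1c(C(=O)N[C@@H](CO)CCO)ccc1C(CC)(CC)c1ccc(OCS(=O)(=O)c2ccccc2)c(C)c1` keeps the core and changes that same place: 3-hydroxy-1-(hydroxymethyl)propyl stands in place of 1-(hydroxymethyl)cyclopropyl, so the ring is gone and the chain is open (3-hydroxy-1-(hydroxymethyl)propyl in place of 1-(hydroxymethyl)cyclopropyl on an amide-type nitrogen). Within the data shown here, no measured step tests this exchange directly. The two large steps show only that this place can shift the number strongly, and the other groups tried there ended at the limit. A moderate move toward a higher number, meaning weaker inhibition, therefore seems more likely than a gain, although it may stay close to the scatter. The expected change is a 2.5-fold higher number from compound 3 to compound 4 (0.40 log units; beyond the scatter). For compound 4 the estimated value is 9000 nM, with an expected range from 2500 nM to 35000 nM.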

Compound 4, half-maximal inhibitory concentration: 14100 nM
For compound 4 the middle estimate is 1.6-fold (0.19 log units) below the measured one; low and high end bracket the measured number.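

In this assay the open 3-hydroxy-1-(hydroxymethyl)propyl group on the amide-type nitrogen does worse than the 1-(hydroxymethyl)cyclopropyl group, with a 4.0-fold higher number from compound 3 to compound 4 (0.60 log units; beyond the scatter) as the cost of the exchange. The open chain still gives a true number, unlike the two other ring-free groups, with an at least 3.5-fold lower number from compound 2 to compound 4 (0.54 log units; beyond the scatter) and an at least 3.5-fold lower number from compound 1 to compound 4 (0.54 log units; beyond the scatter) as the gains, so the three-membered ring is not required for a readable value at this position, although compound 1 and compound 2 show that lacking it can also end at the limit. These last two steps give only minimum sizes, because compound 1 and compound 2 rest on a limit of the assay and not on a number: the limit of > 50000 nM in this assay, at which 2 of the 4 values shown sit.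

The exchange removes the ring and brings in a second oxygen at the same time, so the compounds shown cannot separate the effect of one change from that of the other. Also open, going by these compounds, is how an amine or a carboxylic acid in place of the hydroxymethyl, or a 1-(hydroxymethyl)cyclobutyl group on this nitrogen, would read in this assay on this series.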